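Working notes: from compound 2 to compound 3

The source may report more compounds than this note shows. Statements on the series, on what has been measured and on what is new or still open speak of the compounds shown alone.

Compound 1 `CCOC(=O)CCCCCOc1cccc(CN(C(=O)c2ccc(-c3ccc4c(c3)OCCO4)cc2)C(C)C)c1` gives > 24400 nM as a limit
Compound 2 `CCOC(=O)CCCCCOc1cccc(CN(C(=O)c2ccc(-c3cccc(F)c3)cc2)C(C)C)c1` gives > 26000 nM as a limit

In an ADME assay on HEK293 cells (Homo sapiens) for cytotoxicity, read by CellTiter-Glo and resazurin assay, with a stated time of 72 h (on this read-out lower numbers stand for an effect already at smaller amounts and higher numbers for an effect only at larger amounts of compound), compound 2 stands only at a limit, > 26000 nM and no number. Compound 3 `CCOC(=O)CCCCCOc1cccc(CN(C(=O)c2ccc(-c3ccc(Cl)c(Cl)c3)cc2)C(C)C)c1` differs from it in one place: 3,4-dichlorophenyl in place of 3-fluorophenyl on an aromatic carbon with 3,4-dichlorophenyl in place of 3-fluorophenyl. Within the data shown here, the one measured step that the two limits leave unreadable from compound 1 to compound 2 gives no size to carry over, so no step beyond the scatter is expected in this assay and another limit is likely. The expected step is an at least 1.0-fold lower number from compound 2 to compound 3 (0.01 log units; that floor lies within the scatter) on this reasoning. For compound 3 the estimate is 25000 nM with an expected range from 12000 nM to 50000 nM overall.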

Compound 3, half-maximal effective concentration: > 26000 nM
Compound 3 ended at the assay's limit; the forecaster's own chance of this, stated with the estimate: 70%; middle value at least 1.0-fold (0.01 log units) from the limit.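

In this assay compound 3 gives > 26000 nM, a limit and not a number, so the steps to it from compound 1 and compound 2 cannot be read. The compounds shown leave open whether these aryl replacements change the half-maximal effective concentration at all.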